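Replacing 1H-imidazol-4-yl with thiophen-3-yl on a shared core

A few compounds are considered here, and "the series" means these few. Any claim that something is new, unique, unknown or untested is made for them only; others in the source may bear on it.

Within the data shown here, in a functional assay on DU-145 cells (Homo sapiens), read by sulforhodamine B assay, with a stated time of 5 days (on this read-out lower numbers stand for stronger inhibition of growth and higher numbers for weaker inhibition of growth), compound 2 `OC[C@H]1O[C@@H](n2cc(F)c3c(-c4c[nH]cn4)ncnc32)[C@H](O)[C@@H]1O` gives 890 nM, the higher of the two numbers measured so far, whereas compound 1 `OC[C@H]1O[C@@H](n2cc(F)c3c(-c4ccc[nH]4)ncnc32)[C@H](O)[C@@H]1O` gives 9 nM on the same core. Compound 3 `OC[C@H]1O[C@@H](n2cc(F)c3c(-c4ccsc4)ncnc32)[C@H](O)[C@@H]1O` has thiophen-3-yl in place of 1H-imidazol-4-yl on an aromatic carbon and is still unmeasured. Among the measured compounds shown here, one measured step bears on this change. The step of a 99-fold higher number from compound 1 to compound 2 (2.00 log units; beyond the scatter) is large and lies beyond the scatter, so compound 2 has much weaker growth inhibition than compound 1 with the group that compound 3 gives up. For the measured compounds named here, no compound with thiophen-3-yl has been measured, so the size of the change remains uncertain. In this assay the expected change is a clear fall in the number, with a 22-fold lower number from compound 2 to compound 3 (1.35 log units; beyond the scatter) as the estimated step. For compound 3 the estimated value is 40 nM, with an expected range from 9 nM to 200 nM.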

Compound 3, concentration for 50% growth inhibition: 66 nM
Compound 3: middle estimate off by 1.7-fold (0.22 log units), on the low side, within the range that was stated.
By their numbers in this assay, from the lowest: compound 1; then compound 3; then compound 2.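

In this assay, thiophen-3-yl in place of 1H-imidazol-4-yl gives a 13-fold lower number from compound 2 to compound 3 (1.13 log units; beyond the scatter) and so restores much of the growth inhibition, which shows that this aromatic carbon of the shared core tolerates a five-membered aromatic ring with a sulfur atom and no hydrogen-bond donor. Thiophen-3-yl does not fully match 1H-pyrrol-2-yl, however, as the comparison gives a 7.3-fold higher number from compound 1 to compound 3 (0.87 log units; beyond the scatter) and leaves compound 1 with the lowest number of the three. No measured evidence accounts for these differences between the rings.

The compounds shown leave open whether the attachment point on the sulfur ring matters, which thiophen-2-yl would test, and whether furan-2-yl behaves similarly. They also leave open whether a six-membered ring such as phenyl, or a non-aromatic group such as an amine, would be tolerated here.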